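The source may report more compounds than this note shows. Statements on the series, on what has been measured and on what is new or still open speak of the compounds shown alone.

Of the compounds shown here, three with a shared core have been tested in an ADME assay on RAW264.7 cells (Mus musculus) for cytotoxicity, read by MTT assay, with a stated time of 72 h, tested at 100 uM; on this read-out higher numbers stand for a stronger effect at the one concentration tested and lower numbers for a weaker effect. Compound 1 `O=C(Cn1c(=O)oc2ccccc21)Nc1nc2ccccc2s1` gives 59.6% and compound 2 `O=C(Cn1c(=O)oc2cc(Cl)ccc21)NCc1cccs1` gives 53.6%. Compound 3 `O=C(Cn1c(=O)oc2ccccc21)NCc1ccccn1` gives 38.7%, the lowest of the three numbers, lying beyond the scatter under both compound 2 and compound 1. The next compound, compound 4 `O=C(Cn1c(=O)oc2ccccc21)NCc1cccs1`, differs from compound 3 in a single place: thiophen-2-yl in place of pyridin-2-yl on a saturated chain carbon bound to an amide-type nitrogen. Among the compounds with values here, no measured pair shows this exact change on its own, so the size of the step is uncertain. Compound 2, which also carries the entering group, gives 53.6%, which suggests a move upward. For compound 4 the expected step is a number 9.3 percentage points higher from compound 3 to compound 4 (within the scatter), a small rise that may not exceed the scatter. Compound 4 is therefore estimated at 48%, within a range from 30% to 65%.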

Compound 4, a percentage reported as inhibition, at one concentration (the size of the read-out at that concentration, not a potency): 49.1%
Beside the measured number, compound 4's estimate is 1.1 percentage points below it, within the range that was stated.
By their numbers in this assay, from the lowest: compound 3; then compounds 4, 2 and 1 (each within the scatter of the next, the first and the last beyond it).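

In this assay, the step of a number 10.4 percentage points higher from compound 3 to compound 4 (beyond the scatter) isolates thiophen-2-yl in place of pyridin-2-yl on a saturated chain carbon bound to an amide-type nitrogen and shows that this single change alone moves the read-out. Hydrogen in place of chloro on an aromatic carbon gives the step of a number 4.5 percentage points lower from compound 2 to compound 4 (within the scatter) and so has no effect that can be told from the usual scatter. Nothing available explains either step. Going by these compounds, how a phenyl ring or an amine on a longer chain would read at this place remains open. So does whether chloro would matter alongside pyridin-2-yl.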